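Swapping Methyl for Chloro on the Chalcone Ring

A few compounds are considered here, and "the series" means these few. Any claim that something is new, unique, unknown or untested is made for them only; others in the source may bear on it.

Measured compounds:
- Compound 1, `CNC(=O)c1cc(Oc2ccc(/C=C/C(=O)c3ccc([N+](=O)[O-])cc3)cc2)ccn1`: 54300 nM
- Compound 2, `CNC(=O)c1cc(Oc2ccc(/C=C/C(=O)c3ccc(C)cc3)cc2)ccn1`: 24900 nM
- Compound 3, `CNC(=O)c1cc(Oc2ccc(C(=O)/C=C/c3ccc(C#N)cc3)cc2)ccn1`: 9520 nM

These three compounds were tested in a functional assay on MCF7 cells (Homo sapiens) for cytotoxicity, read by MTT assay, with a stated time of 72 h; on this read-out higher numbers stand for weaker inhibition and lower numbers for stronger inhibition. Among them, compound 2 holds the second highest number of the three. Its nearest neighbour is compound 1, whose number is higher by a 2.2-fold lower number from compound 1 to compound 2 (0.34 log units; beyond the scatter). Among the measured compounds shown here, compound 3 stands furthest from it, with a number that is lower than that of compound 2; no single-change step links those two, so their values simply show that gap.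

The new compound, compound 4, `CNC(=O)c1cc(Oc2ccc(/C=C/C(=O)c3ccc(Cl)cc3)cc2)ccn1`, differs from compound 2 in one place: chloro in place of methyl on an aromatic carbon. For the measured compounds named here, the only step measured so far on this position puts methyl in place of nitro, and it moved the number by a 2.2-fold lower number from compound 1 to compound 2 (0.34 log units; beyond the scatter), a modest shift. Going by the values given here, no measured step places chloro on this ring, so there is no direct precedent for the change to compound 4. Among the compounds with values here, the one relevant step being modest, a small step is expected in this assay, either way, most likely not beyond the scatter; the estimated change from compound 2 to compound 4 is a 1.2-fold lower number from compound 2 to compound 4 (0.10 log units; within the scatter). Compound 4 is therefore expected to give about 20000 nM, within a range of 8000 nM to 50000 nM.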

Compound 4, half-maximal inhibitory concentration: 17500 nM
The estimate for compound 4 lay 1.1-fold (0.06 log units) above the measured number; the measured number falls inside the stated range.
By their numbers in this assay, from the lowest: compounds 3, 4 and 2 (each within the scatter of the next, the first and the last beyond it); then compound 1.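

In this assay, the change from methyl to chloro at this ring position leaves the read-out within the usual scatter (a 1.4-fold lower number from compound 2 to compound 4 (0.15 log units; within the scatter)), so the data cannot separate these two groups here. Before this result, nitro and methyl were the only groups compared at this position; chloro now provides a second comparison with nitro, and that step is also modest but beyond the scatter (a 3.1-fold lower number from compound 1 to compound 4 (0.49 log units; beyond the scatter)). Among the three compounds that differ only in this group, compound 1 therefore stands apart from both compound 2 and compound 4, but no measurement shown here explains that difference.

From the compounds shown here alone, it remains open whether a methoxy group or an amine on the same ring carbon would give a number close to those of compound 2 and compound 4 or one closer to that of compound 1. Compound 3 differs from the others in more than one place, so it cannot show what a nitrile alone would do at this position, or whether the chloro and methyl result would hold on its differently arranged core.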